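Working notes on two measured compounds and one expectation

The compounds below may be only part of what the source reports. "The series", "measured", "known", "first", "only" and "open" are said of these compounds alone.

The three compounds share one core that carries a 1H-indol-3-yl group and differ only in the group on a saturated ring carbon. Compound 1 is `COc1cc(Br)c(C2C(C#N)=C(N)OC(c3c[nH]c4ccccc34)=C2C#N)cc1OC` and compound 2 is `CN(C)c1ccc(C2C(C#N)=C(N)OC(c3c[nH]c4ccccc34)=C2C#N)cc1`. In a functional assay, tested at 100 ug/mL (on this read-out higher numbers stand for a stronger effect at the one concentration tested and lower numbers for a weaker effect), compound 1 gives 20.5%. In this assay compound 2 gives 18.5%. The number of compound 2 stands a little under that of compound 1, a gap that lies within the usual scatter, so the two compounds cannot be told apart and no change can be read from the pair. Both numbers stand for a modest effect at the single concentration tested.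

Compound 3, not yet measured, is `N#CC1=C(N)OC(c2c[nH]c3ccccc23)=C(C#N)C1c1cccc2ccccc12`. Against compound 2 it differs as follows: naphthalen-1-yl in place of 4-(dimethylamino)phenyl on a saturated ring carbon. Among the measured compounds shown here, no measured pair shows what such an entry does, and the two numbers at hand give no direction for it. The expected step of a number 1.5 percentage points higher from compound 2 to compound 3 (within the scatter) is therefore estimated to be none beyond the scatter. In this assay compound 3 is estimated at 20%, with a range from 8% to 35%.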

Compound 3, a percentage reported as activity, at one concentration (the size of the read-out at that concentration, not a potency): 6.8%
Estimate against measurement, compound 3: 13.2 percentage points above, and the stated range ends above it.
By their numbers in this assay, from the lowest: compound 3; then compounds 2 and 1 (each within the scatter of the next).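

In this assay, among the compounds shown here, naphthalen-1-yl in place of 4-(dimethylamino)phenyl on a saturated ring carbon gives a number 11.7 percentage points lower from compound 2 to compound 3 (beyond the scatter) and is the first change to lie beyond the scatter, so the group at this position can move the read-out, which the two earlier numbers could not show. The change replaces one six-membered aromatic ring of carbon only, bearing a dimethylamino group, with two such rings and leaves the entering group with no hydrogen-bond acceptor, and this one step does not separate these differences. Nothing measured here bears on the cause of the lower number.

Going by these compounds, it remains open whether the lower number goes with the second aromatic ring or with the loss of the dimethylamino group, a question that an unsubstituted phenyl group at this position would address more directly than the present pair. Also open, on these data alone, is how naphthalen-2-yl, which keeps the same two rings, or a phenyl group bearing a carboxylic acid would compare with compound 2 and compound 3 on this read-out.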